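Thiophenylmethylamino Urea Variant of a Piperidinyl Aniline Series

A few compounds are considered here, and "the series" means these few. Any claim that something is new, unique, unknown or untested is made for them only; others in the source may bear on it.

Compound 1 `CC(=O)N1CCN(C(=O)Nc2ccc(N3CCC(N4CCCC4C)C3)cc2)CC1` is the starting point of this comparison. In an assay on CHO cells for displacement of a labelled ligand from histamine receptor H3 (Macaca mulatta), read by scintillation counting, with a stated time of 1 h (on this read-out higher numbers stand for weaker inhibition and lower numbers for stronger inhibition), compound 1 gives 34.1 nM, the higher of the two numbers recorded so far. Among the measured compounds shown here, its only measured neighbour is compound 2 `CC1CCCN1C1CCN(c2ccc(NC(=O)N3CCN(c4ccccc4)CC3)cc2)C1`, which in this assay gives 10.6 nM; the step of a 3.2-fold lower number from compound 1 to compound 2 (0.51 log units; beyond the scatter) comes from exchanging the acetyl on the ring amine nitrogen for phenyl. Compound 3 `CC1CCCN1C1CCN(c2ccc(NC(=O)NCc3cccs3)cc2)C1` has not yet been measured. It differs from compound 1 as follows: ((thiophen-2-yl)methyl)amino in place of 4-acetylpiperazin-1-yl on a carbonyl carbon. For the measured compounds named here, the one measured step touches the same end of the molecule, where a group carrying a six-membered aromatic ring in place of acetyl gave the modest gain seen in a 3.2-fold lower number from compound 1 to compound 2 (0.51 log units; beyond the scatter). Going by the values given here, the change to compound 3 also removes the six-membered non-aromatic ring and brings in a hydrogen-bond donor, for which there is no measured precedent. A step in the same direction as a 3.2-fold lower number from compound 1 to compound 2 (0.51 log units; beyond the scatter), but no larger, is therefore expected for compound 3, about a 1.7-fold lower number from compound 1 to compound 3 (0.23 log units; within the scatter). Compound 3 is estimated to give 20 nM in this assay, with a plausible range from 6 nM to 60 nM.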

Compound 3, inhibition constant: 1.9 nM
Beside the measured number, compound 3's estimate is 11-fold (1.02 log units) above it, outside the stated range (below it).
By their numbers in this assay, from the lowest: compound 3; then compound 2; then compound 1.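

In this assay, exchanging 4-acetylpiperazin-1-yl on a carbonyl carbon for ((thiophen-2-yl)methyl)amino gives an 18-fold lower number from compound 1 to compound 3 (1.25 log units; beyond the scatter), a large step, whereas a 3.2-fold lower number from compound 1 to compound 2 (0.51 log units; beyond the scatter) is a modest one. This position therefore does not need the six-membered non-aromatic ring with 2 hetero atoms that compounds 1 and 2 share: compound 3 has lost it and gives 1.9 nM, while compound 2 keeps it and gives 10.6 nM in the same assay. A smaller group with a five-membered aromatic ring and a hydrogen-bond donor is thus well accepted on this carbonyl carbon, and of the three compounds shown, compound 3 has the lowest number.

The single step changes the ring, the link to it and the hydrogen-bond donor together, so the compounds shown leave open which of these carries the gain. Replacing the thiophene with a furan or a phenyl ring, lengthening the methylene link to an ethylene chain, or placing a methyl group on the nitrogen would each separate these parts. No measurement here speaks to the cause of the step.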